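This account rests on a few compounds, and the source may have more. Where it says the series, first, only, none or still open, it means among the compounds named here.

Going by the values given here, compound 1, `CCCNC(=O)C1CCN(C(=O)c2cc3sc(-c4ccccc4)cc3n2Cc2ccc(OC)cc2)CC1`, is one of two compounds measured in an ADME assay on microsomes from liver (Homo sapiens) for metabolic stability (on this read-out lower numbers stand for a shorter-lived compound and higher numbers for a longer-lived compound), and in this assay compound 1 gives 0.737 h. The other, compound 2, `CCCNC(=O)C1CN(C(=O)c2cc3sc(Br)cc3n2Cc2ccc(OC)cc2)C1`, is built on a smaller ring in the amide part and carries bromine where compound 1 carries phenyl; in this assay compound 2 gives 0.129 h. Compound 1 therefore stands with the higher of the two numbers, and the gap to compound 2 lies well beyond the scatter of the measurement. Compound 3, `CCCNC(=O)C1CCN(C(=O)c2cc3sccc3n2Cc2ccc(OC)cc2)CC1`, has not yet been measured. It differs from compound 1 in one place: hydrogen in place of phenyl on an aromatic carbon. Among the compounds with values here, no measured pair shows this change on its own, and compound 2 cannot stand in for it since it differs in more than one place. The step from compound 1 to compound 3 is expected to be small, within the scatter, a 1.5-fold lower number from compound 1 to compound 3 (0.17 log units; within the scatter), leaning slightly toward the shorter-lived side. On that basis compound 3 is estimated at 0.5 h, with a range of 0.2 h to 1.2 h.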

Compound 3, half-life: 0.177 h
Compound 3: middle estimate off by 2.8-fold (0.45 log units), on the high side, and the stated range ends above it.
By their numbers in this assay, from the lowest: compounds 2 and 3 (each within the scatter of the next); then compound 1.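

Read in this assay, hydrogen in place of phenyl on this aromatic carbon, next to the ring sulfur, gives a 4.2-fold lower number from compound 1 to compound 3 (0.62 log units; beyond the scatter). Going by these compounds alone, this is the first step that isolates a single change, and it shows that on the core of compound 1 this position is not neutral for the half-life: the phenyl goes with the longer-lived compound. Nothing shown here explains the step. Going by these compounds, whether that holds for phenyl alone remains open, since a methyl, a chlorine or a pyridine ring on the same carbon could give a number near either compound 1 or compound 3. Also open, on these data alone, is whether the same change would give a step of similar size with the smaller amide ring of compound 2.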